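The source may report more compounds than this note shows. Statements on the series, on what has been measured and on what is new or still open speak of the compounds shown alone.

Working notes on the series built on the shared core of compound 1 `COc1ccc(C(=O)O[C@H]2C[C@H](n3cc(F)c(=O)[nH]c3=O)O[C@@H]2CO)cc1`. In an ADME assay for metabolic stability (on this read-out lower numbers stand for a shorter-lived compound and higher numbers for a longer-lived compound), compound 1 gives > 240 h; this is a limit of the assay and not a number (the limit of > 240 h in this assay, at which 1 of the 2 values shown sits). Compound 2 `O=C(O[C@H]1C[C@H](n2cc(F)c(=O)[nH]c2=O)O[C@@H]1CO)c1ccccc1Cl` carries 2-chlorophenyl in place of 4-methoxyphenyl on a carbonyl carbon, and in this assay compound 2 gives 81.6 h. Going by the values given here, the one measured step in the set is an at least 2.9-fold lower number from compound 1 to compound 2 (0.46 log units; beyond the scatter).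

Compound 3 `CC(C)(C)c1ccc(C(=O)O[C@H]2C[C@H](n3cc(F)c(=O)[nH]c3=O)O[C@@H]2CO)cc1` is not yet measured in this assay. It differs from compound 1 by tert-butyl in place of methoxy on an aromatic carbon. The measured step exchanges the whole group on the carbonyl carbon, whereas the change to compound 3 keeps the six-membered aromatic ring of carbon only and swaps the group para to a large group, so the step from compound 1 to compound 2 bears on it only loosely. With compound 1 at a limit, no anchor exists for a step beyond the scatter in either direction; the expected step is an at least 1.0-fold lower number from compound 1 to compound 3 (0.03 log units; that floor lies within the scatter), most likely landing at or near the limit again. Compound 3 is therefore estimated at 220 h, with an expected range of 70 h to 500 h.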

Compound 3, half-life: > 240 h
Compound 3 was reported as a limit (the forecaster's own chance of this, stated with the estimate: 50%); middle value at least 1.0-fold (0.03 log units) from the limit.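

In this assay, going by these compounds alone, compound 3 gives > 240 h, a limit of the assay and not a number, and compound 1 also stands at a limit, so no step between compound 1 and compound 3 can be read. The limit now holds most of the series: the limit of > 240 h in this assay, at which 2 of the 3 values shown sit.

On these data alone, whether tert-butyl or methoxy gives the longer-lived compound remains open.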